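A few compounds are considered here, and "the series" means these few. Any claim that something is new, unique, unknown or untested is made for them only; others in the source may bear on it.

Compound 1 `O=C1N=C(N2CCC[C@H]2C(=O)Nc2ccc3ncnc(Nc4cccc(Cl)c4)c3c2)S/C1=C/c1ccccc1F`: 18200 nM
Compound 2 `O=C1N=C(N2CCC[C@H]2C(=O)Nc2ccc3ncnc(Nc4cccc(Cl)c4)c3c2)S/C1=C/c1ccccc1[N+](=O)[O-]`: 32500 nM
Compound 3 `O=C1N=C(N2CCC[C@H]2C(=O)Nc2ccc3ncnc(Nc4cccc(Cl)c4)c3c2)S/C1=C/c1cccc(Br)c1`: 21300 nM

These three compounds share one core and differ only in the ring held on a double-bonded chain carbon bound to a double-bonded ring carbon. In a functional assay on HepG2 cells (Homo sapiens) for antiproliferative activity, read by MTT assay (a lower number here means a stronger inhibitor, a higher number a weaker inhibitor), compound 1 gives the lowest of the three numbers, yet both other values lie within the scatter of it: a 1.8-fold higher number from compound 1 to compound 2 (0.25 log units; within the scatter) and a 1.2-fold higher number from compound 1 to compound 3 (0.07 log units; within the scatter), as does a 1.5-fold lower number from compound 2 to compound 3 (0.18 log units; within the scatter). Compound 4 `O=C1N=C(N2CCC[C@H]2C(=O)Nc2ccc3ncnc(Nc4cccc(Cl)c4)c3c2)S/C1=C/c1cccnc1Cl` has not been measured. It differs from compound 1 by 2-chloropyridin-3-yl in place of 2-fluorophenyl on a double-bonded chain carbon bound to a double-bonded ring carbon. All three measured steps exchange the ring at this same place and all stay within the scatter, so no step beyond the scatter is expected from this exchange either: a 1.1-fold higher number from compound 1 to compound 4 (0.04 log units; within the scatter). Compound 4 is therefore expected at about 20000 nM, within 9000 nM to 45000 nM.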

Compound 4, half-maximal inhibitory concentration: 6400 nM
Compound 4: middle estimate off by 3.1-fold (0.49 log units), on the high side; measured number below the stated range.
By their numbers in this assay, from the lowest: compound 4; then compounds 1, 3 and 2 (each within the scatter of the next).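

In this assay, the ring at this position can shift the number after all: a 2.8-fold lower number from compound 1 to compound 4 (0.45 log units; beyond the scatter) and a 3.3-fold lower number from compound 3 to compound 4 (0.52 log units; beyond the scatter) and a 5.1-fold lower number from compound 2 to compound 4 (0.71 log units; beyond the scatter). Among the four rings, only the entering 2-chloropyridin-3-yl has a hetero atom in the ring itself, so exchanges at this place are not all alike. Nothing available explains why this ring gives the lower number.

The ring nitrogen and the chlorine enter together, so the compounds shown cannot tell which of them matters. A plain pyridine ring and a chlorophenyl ring would separate the two.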